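Benzyl for propyl on the ring amine of compound 3

The source may report more compounds than this note shows. Statements on the series, on what has been measured and on what is new or still open speak of the compounds shown alone.

Compound 3 `CCCN1CC[C@@]2(OC)OC(N)=C(C#N)[C@@H](c3ccc(OC)cc3)[C@@H]2C1` stands second highest of the three numbers in a functional assay on trachea (Cavia porcellus) (on this read-out lower numbers stand for stronger inhibition and higher numbers for weaker inhibition), where compound 3 gives 21300 nM; compound 1 `CO[C@@]12CCN(Cc3ccccc3)C[C@H]1[C@H](c1ccccc1)C(C#N)=C(N)O2` gives 22600 nM and compound 2 `CO[C@@]12CCN(Cc3ccccc3)C[C@H]1[C@H](c1ccc(F)cc1)C(C#N)=C(N)O2` gives 17200 nM, both within the scatter of it. Compound 4 `COc1ccc([C@@H]2C(C#N)=C(N)O[C@]3(OC)CCN(Cc4ccccc4)C[C@@H]23)cc1` differs from compound 3 by phenyl in place of ethyl on a saturated chain carbon bound to an amine nitrogen in a ring. Among the measured compounds shown here, no measured step touches that place: the only step, a 1.3-fold lower number from compound 1 to compound 2 (0.12 log units; within the scatter), concerns a fluoro on an aromatic carbon and lies within the scatter. Because compound 1 also carries the benzyl group and gives 22600 nM, and compound 2 carries it too and gives 17200 nM, both at the same level as compound 3, little change is expected. Compound 4 is expected to show a 1.1-fold lower number from compound 3 to compound 4 (0.03 log units; within the scatter). Compound 4 is therefore estimated at 20000 nM, ranging from 8000 nM to 50000 nM.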

Compound 4, half-maximal inhibitory concentration: 23100 nM
For compound 4 the middle estimate is 1.2-fold (0.06 log units) below the measured one; the range from low to high includes it.
By their numbers in this assay, from the lowest: compounds 2, 3, 1 and 4 (each within the scatter of the next).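

Phenyl in place of ethyl on a saturated chain carbon bound to an amine nitrogen in a ring gives a 1.1-fold higher number from compound 3 to compound 4 (0.04 log units; within the scatter) in this assay and so this change, propyl to benzyl, leaves the number within the scatter at this position. With benzyl held, methoxy on the aromatic carbon gives a 1.0-fold higher number from compound 1 to compound 4 (0.01 log units; within the scatter) against hydrogen and a 1.3-fold higher number from compound 2 to compound 4 (0.13 log units; within the scatter) against fluoro on that carbon. Nothing available explains why these numbers stay together.

The compounds shown leave open whether a longer chain ending in an amine in this place, or a carboxylic acid on the aromatic carbon, would move the number beyond the scatter.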